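Benzamide variation on the shared core: towards compound 4

The source may hold more compounds than are shown below. What is called first, only, known or untested is meant among the compounds shown, and "the series" means these compounds.

Compound 2 `COc1ccccc1C(=O)Nc1ccc(Sc2nc3ccccc3s2)cc1` is one of three measured analogues; compound 1 `O=C(Nc1ccc(Sc2nc3ccccc3s2)c(Cl)c1)c1cccc(Br)c1O` and compound 3 `COc1ccccc1C(=O)Nc1ccc(Sc2nc3ccccc3s2)c(Cl)c1` both carry a chloro on the core. In an assay on isolated protein for inhibition of thiosulfate sulfurtransferase (Homo sapiens), with a stated time of 60 min, in the absence of a further agent (on this read-out higher numbers stand for weaker inhibition and lower numbers for stronger inhibition), compound 1 gives only a limit of > 100000 nM. Compound 2 likewise reaches only a limit of > 100000 nM in this assay. Compound 3 also stops at a limit of > 100000 nM in this assay. The steps a step that the two limits leave unreadable from compound 1 to compound 3 and a step that the two limits leave unreadable from compound 2 to compound 3 are therefore unreadable, and compound 2 stands only at the limit of > 100000 nM in this assay, at which 3 of the 3 values shown sit. Compound 4 `O=C(Nc1ccc(Sc2nc3ccccc3s2)cc1)c1cccc(Br)c1` differs from compound 2 by 3-bromophenyl in place of 2-methoxyphenyl on a carbonyl carbon. Among the compounds with values here, no measured step bears on this change. With every value at the limit, the step that the limit leaves unreadable from compound 2 to compound 4 is expected to show no shift beyond the scatter. Compound 4 is thus estimated at 200000 nM, range 30000 nM to 2000000 nM.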

Compound 4, half-maximal inhibitory concentration: > 100000 nM
Compound 4: a limit, no number; the forecaster's own chance of this, stated with the estimate: 75%; the middle value is on the limit's open side.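

Compound 2 and compound 4 both stop at a limit in this assay, and the step between them cannot be read. The compounds shown leave open whether any group on the carbonyl carbon gives a measurable inhibition value.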